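An ester and its acid at the detection limit

The compounds below may be only part of what the source reports. "The series", "measured", "known", "first", "only" and "open" are said of these compounds alone.

Compound 2 `CCOC(=O)c1cccc(OCC(CC)OC(=O)NCc2ccccc2)c1` has only a limit, not a number: in an assay for inhibition of zeta-carotene desaturase, chloroplastic/chromoplastic (Capsicum annuum), using a Dixon plot, with a stated time of 8 h (on this read-out higher numbers stand for weaker inhibition and lower numbers for stronger inhibition), compound 2 gives > 100000 nM. Its neighbour compound 1 `CCC(COc1cccc(F)c1)OC(=O)NCc1ccccc1` also stops at a limit, and in this assay compound 1 gives > 100000 nM. The step that the two limits leave unreadable from compound 1 to compound 2 therefore cannot be read, since both values sit at the limit of > 100000 nM in this assay, at which 2 of the 2 values shown sit. The change to compound 3 `CCC(COc1cccc(C(=O)O)c1)OC(=O)NCc1ccccc1` is hydrogen in place of ethyl on an oxygen next to a carbonyl group, so that the ethoxycarbonyl group of compound 2 becomes a carboxy group. Among the measured compounds shown here, no measured step bears on this change, and the one recorded step gives no direction. With both neighbours at the limit, compound 3 is expected to stay there, and the expected step that the limit leaves unreadable from compound 2 to compound 3 is taken as no change beyond the scatter. The estimate for compound 3 in this assay is 150000 nM, within a range from 50000 nM to 500000 nM, most likely reported again only as a limit.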

Compound 3, half-maximal inhibitory concentration: > 100000 nM
Compound 3: only a limit was reported (the forecaster's own chance of this, stated with the estimate: 85%); the middle value lies beyond the limit too.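

In this assay compound 3 gives > 100000 nM, which is a limit and not a number, so the steps among compound 1, compound 2 and compound 3 cannot be read: the limit of > 100000 nM in this assay, at which 3 of the 3 values shown sit.

The compounds shown leave open how fluoro, ethoxycarbonyl and carboxy on the shared core actually compare in this assay.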